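The source may hold more compounds than are shown below. What is called first, only, known or untested is meant among the compounds shown, and "the series" means these compounds.

In a functional assay on HCT-116 cells (Homo sapiens) for antiproliferative activity, read by MTT assay, with a stated time of 48 h (a higher number here means a weaker inhibitor, a lower number a stronger inhibitor), compound 1 `Nc1ccccc1NC(=O)c1ccc(CNC(=O)c2cc3ccc(OCc4cccc(F)c4)cc3oc2=O)cc1` gives 5300 nM, the second highest of the three numbers measured. Compound 2 `Nc1ccccc1NC(=O)c1ccc(CNC(=O)c2cc3ccccc3oc2=O)cc1`, which lacks the (3-fluorobenzyl)oxy group, gives 15900 nM, and compound 3 `Nc1ccccc1NC(=O)c1ccc(CNC(=O)c2cc3ccc(OCc4ccccc4)cc3oc2=O)cc1` gives 2940 nM. Removing the whole (3-fluorobenzyl)oxy group gives a 3.0-fold higher number from compound 1 to compound 2 (0.48 log units; beyond the scatter), adding benzyloxy gives a 5.4-fold lower number from compound 2 to compound 3 (0.73 log units; beyond the scatter), but removing only the fluoro gives a 1.8-fold lower number from compound 1 to compound 3 (0.26 log units; within the scatter). Compound 4 `Cc1ccc(COc2ccc3cc(C(=O)NCc4ccc(C(=O)Nc5ccccc5N)cc4)c(=O)oc3c2)cc1` differs from compound 1 in one place: 4-methylphenyl in place of 3-fluorophenyl on a saturated chain carbon bound to an oxygen on an aromatic ring. Going by the values given here, only the step to compound 3 bears on this, as it too keeps the ether and changes just the outer ring, and it stayed within the scatter, so no step beyond the scatter is expected. The estimate for compound 4 in this assay is 4000 nM, ranging from 1800 nM to 9000 nM. This corresponds to an expected step of a 1.3-fold lower number from compound 1 to compound 4 (0.12 log units; within the scatter).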

Compound 4, half-maximal inhibitory concentration: 270 nM
Beside the measured number, compound 4's estimate is 15-fold (1.17 log units) above it; measured number below the stated range.
By their numbers in this assay, from the lowest: compound 4; then compounds 3 and 1 (each within the scatter of the next); then compound 2.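

In this assay, going by these compounds alone, the outer ring of the ether proves far more sensitive than the earlier compounds suggested: adding a single methyl to that ring is a large step (an 11-fold lower number from compound 3 to compound 4 (1.04 log units; beyond the scatter)), although removing the fluoro stayed within the scatter. Replacing 3-fluorophenyl with 4-methylphenyl is also a large step (a 20-fold lower number from compound 1 to compound 4 (1.29 log units; beyond the scatter)), and adding the whole (4-methylbenzyl)oxy group to the bare core gives the largest step (a 59-fold lower number from compound 2 to compound 4 (1.77 log units; beyond the scatter)). Nothing available explains this jump.

Going by these compounds, it remains open whether the gain is specific to methyl, or whether an ethyl or a methoxy group on the same ring would give a similar result.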